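A few compounds are considered here, and "the series" means these few. Any claim that something is new, unique, unknown or untested is made for them only; others in the source may bear on it.

Compound 1 `O=C(c1ccc(O)cc1)c1ccn(-c2ccc3c(c2)B(O)OC3)c1` in an ADME assay on L929 cells (Mus musculus) for cytotoxicity, read by resazurin assay, with a stated time of 72 h (on this read-out higher numbers stand for weaker inhibition and lower numbers for stronger inhibition), gives > 10 ug/mL, which is a limit of the assay and not a number. Compound 2 `Nc1ccc(C(=O)c2ccn(-c3ccc4c(c3)B(O)OC4)c2)cc1` gives 3.9 ug/mL. Compound 3 `O=C(c1ccn(-c2ccc3c(c2)B(O)OC3)c1)C1CCCCC1` gives > 10 ug/mL, again only a limit.

Compound 3 therefore stands at the limit of > 10 ug/mL in this assay, at which 2 of the 3 values shown sit. Its steps to the others are a step that the two limits leave unreadable from compound 1 to compound 3 and an at least 2.5-fold higher number from compound 2 to compound 3 (0.40 log units; beyond the scatter). Compound 4 `Cc1ccsc1C(=O)c1ccn(-c2ccc3c(c2)B(O)OC3)c1` differs from compound 3 by 3-methylthiophen-2-yl in place of cyclohexyl on a carbonyl carbon. Among the compounds with values here, no measured step exchanges the group on the carbonyl carbon for an aromatic ring of this kind; the only readable step, an at least 2.5-fold lower number from compound 1 to compound 2 (0.40 log units; beyond the scatter), sits elsewhere. Both aromatic ketones, compound 1 and compound 2, give either the limit or a modest number, so compound 4 is expected to give 12 ug/mL (range 4 ug/mL to 30 ug/mL), an expected step that the limit leaves unreadable from compound 3 to compound 4 likely not readable beyond the scatter.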

Compound 4, half-maximal inhibitory concentration: > 10 ug/mL
Compound 4: a limit, no number; the forecaster's own chance of this, stated with the estimate: 60%; the middle value is on the limit's open side.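

In this assay compound 4, with 3-methylthiophen-2-yl on the carbonyl carbon, gives > 10 ug/mL, which is a limit of the assay and not a number. Within the data shown here, an aromatic ring without the 4-amino group thus gives no number here, and the one readable change is an at least 2.5-fold higher number from compound 2 to compound 4 (0.40 log units; beyond the scatter). The steps from compound 1 and from compound 3 to compound 4 cannot be read, and the limit is now the usual result: the limit of > 10 ug/mL in this assay, at which 3 of the 4 values shown sit.

The compounds shown leave open whether another amine on the carbonyl carbon, such as aminomethyl, would also give a number. They also cannot rank the groups that sit at the limit.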